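Swapping One Aryl Group on a Diacetylamino Compound

The source may report more compounds than this note shows. Statements on the series, on what has been measured and on what is new or still open speak of the compounds shown alone.

In a functional assay on K562 cells (Homo sapiens) for cytotoxicity, read by MTT assay, with a stated time of 48 h (a higher number here means a weaker inhibitor, a lower number a stronger inhibitor), compound 1 `COc1cc(-c2noc(N)c2-c2ccc(Cl)cc2)cc(OC)c1OC` gives 640 nM, while compound 2 `COc1ccc(-c2c(-c3cc(OC)c(OC)c(OC)c3)noc2N(C(C)=O)C(C)=O)cc1OC` gives 4290 nM, the higher of the two numbers and so the weaker inhibitor. Compound 3 `COc1cc(-c2noc(N(C(C)=O)C(C)=O)c2-c2ccc(Cl)cc2)cc(OC)c1OC` keeps the diacetylamino group of compound 2 but carries 4-chlorophenyl in place of 3,4-dimethoxyphenyl on an aromatic carbon. Compound 1 also carries 4-chlorophenyl and gives 640 nM, so a modest shift toward stronger inhibition seems likely. In this assay, the estimated shift is a 2.0-fold lower number from compound 2 to compound 3 (0.29 log units; within the scatter). For compound 3, the expected value is 2200 nM, within an estimated range of 700 nM to 6500 nM.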

Compound 3, half-maximal inhibitory concentration: 3960 nM
Compound 3: the middle estimate sits 1.8-fold (0.26 log units) below what was measured; low and high end bracket the measured number.
By their numbers in this assay, from the lowest: compound 1; then compounds 3 and 2 (each within the scatter of the next).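

With the diacetylamino group in place, the swap of aryl group gives a 1.1-fold lower number from compound 2 to compound 3 (0.03 log units; within the scatter) in this assay and so shows no readable difference between 3,4-dimethoxyphenyl and 4-chlorophenyl at this position. For the compounds shown here, with 4-chlorophenyl held fixed, diacetylamino in place of amino gives a 6.2-fold higher number from compound 1 to compound 3 (0.79 log units; beyond the scatter) and is the one change here that moves the number beyond the scatter. No supporting evidence is available to explain either result. From the compounds shown here alone, whether the aryl swap would matter on a compound carrying the free amino group stays open. So does how a single acetylamino group or a plain phenyl would read.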